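Ring expansion of the 2-oxopyrrolidin-1-yl group

This account rests on a few compounds, and the source may have more. Where it says the series, first, only, none or still open, it means among the compounds named here.

Measured so far in an assay on CHO cells for displacement of a labelled ligand from prostaglandin E2 receptor EP1 subtype (Homo sapiens); on this read-out lower numbers stand for stronger inhibition and higher numbers for weaker inhibition:
Compound 1, `Cc1ccc(-c2cc(Br)ccc2OCc2ccc(F)cc2)n1-c1cc(C(=O)O)ccc1F`, gives 6.31 nM.
Compound 2, `Cc1ccc(-c2cc(Br)ccc2OCc2ccc(F)cc2F)n1-c1cc(C(=O)O)cc(N2CCCC2=O)c1`, gives 2 nM.
Compound 3, `CC(=O)Nc1cc(C(=O)O)cc(-n2c(C)ccc2-c2cc(Cl)ccc2OCc2ccc(F)cc2)c1`, gives 2.51 nM.

Compound 2 carries the lowest of the three numbers in this assay. Its nearest neighbour is compound 3, whose number lies within the scatter of that of compound 2, so no order between these two can be read. Compound 1 stands furthest off, with a number beyond the scatter above that of compound 2.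

Compound 4, `Cc1ccc(-c2cc(Br)ccc2OCc2ccc(F)cc2F)n1-c1cc(C(=O)O)cc(N2CCCCC2=O)c1`, has not been measured in this assay. It differs from compound 2 in one place: 2-oxopiperidin-1-yl in place of 2-oxopyrrolidin-1-yl on an aromatic carbon. The five-membered non-aromatic ring leaves and a six-membered non-aromatic ring enters, with the same count of hydrogen-bond donors and acceptors and no net charge.

Among the compounds with values here, no measured pair shows this change, so its size is unknown from the data. The step from compound 2 to compound 4 is expected to be small, a 1.3-fold higher number from compound 2 to compound 4 (0.10 log units; within the scatter), within the scatter and in no clear direction. Compound 4 is estimated at 2.5 nM, in the range 1 nM to 6.3 nM.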

Compound 4, half-maximal inhibitory concentration: 1.26 nM
Beside the measured number, compound 4's estimate is 2.0-fold (0.30 log units) above it, within the range that was stated.
By their numbers in this assay, from the lowest: compounds 4, 2 and 3 (each within the scatter of the next); then compound 1.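

In this assay, 2-oxopiperidin-1-yl in place of 2-oxopyrrolidin-1-yl gives a 1.6-fold lower number from compound 2 to compound 4 (0.20 log units; within the scatter), so no order between these two compounds can be read. Within the data shown here, this is the first pair that isolates the group on this aromatic carbon, meta to a carboxy group, and it shows that the six-membered ring is accepted there without a change that can be told from the scatter. Nothing available explains the size of this step.

Still open, from the compounds shown here alone, is how far this tolerance extends, for instance to the seven-membered 2-oxoazepan-1-yl, to 3-oxomorpholin-4-yl with an added ring oxygen, or to a basic amine such as piperidin-1-yl with no carbonyl. Going by these compounds, it is also open whether the same ring change gives a similar step when the shared core carries chlorine in place of bromine.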